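Bromine for Fluorine on Two Pyridine Rings

This account rests on a few compounds, and the source may have more. Where it says the series, first, only, none or still open, it means among the compounds named here.

Compound 1 `Fc1ncc(OC[C@@H]2CCN2)cc1-c1cccnc1` and compound 2 `Brc1ncc(OC[C@@H]2CCN2)cc1-c1cccnc1` differ in a single place, and compound 3 `Fc1ccc(-c2cc(OC[C@@H]3CCCN3)cnc2Cl)cn1` and compound 4 `Clc1ncc(OC[C@@H]2CCCN2)cc1-c1ccc(Br)nc1` form a second pair. In an assay on membranes from brain with Neuronal acetylcholine receptor; alpha4/beta2 (Rattus norvegicus) as the target (a higher number here means a weaker inhibitor, a lower number a stronger inhibitor), compound 1 gives 0.066 nM, and compound 2 gives 0.0066 nM. The change between them is bromo in place of fluoro on an aromatic carbon and it produced a 10-fold lower number from compound 1 to compound 2 (1.00 log units; beyond the scatter). Measured in this assay, compound 3 gives 0.0179 nM, a higher number than compound 2 and a lower one than compound 1. The difference between the core of compound 1 and the core of compound 3 is not broken down here. Compound 4 has not yet been measured in this assay. The change from compound 3 to compound 4 is bromo in place of fluoro on an aromatic carbon. It is the same kind of change as in the first pair, but the surroundings differ: there the place is ortho to a pyridin-3-yl group and para to a (azetidin-2-yl)methoxy group, here it is para to a large group. Because the earlier change gave a 10-fold lower number from compound 1 to compound 2 (1.00 log units; beyond the scatter), a lower number is expected again, though in different surroundings, so compound 4 is expected to show a smaller move, estimated at a 3.0-fold lower number from compound 3 to compound 4 (0.47 log units; beyond the scatter). Compound 4 is thus estimated at 0.006 nM, within 0.002 nM to 0.02 nM.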

Compound 4, inhibition constant: 0.0195 nM
Beside the measured number, compound 4's estimate is 3.3-fold (0.51 log units) below it; the range from low to high includes it.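

On the second pair, the exchange of fluoro for bromo leaves no readable difference in this assay: the step is a 1.1-fold higher number from compound 3 to compound 4 (0.04 log units; within the scatter). The sharp drop seen on the first pair did not carry over to the second, and the two steps are truly different: the same change on two cores in this assay, a 10-fold lower number (1.00 log units; beyond the scatter) from compound 1 to compound 2 and a 1.1-fold higher number (0.04 log units; within the scatter) from compound 3 to compound 4, 11-fold (1.04 log units) apart, beyond the scatter of two such steps

This shows that, in this series, the size of the step from this change cannot simply be transferred from one core to another. It does not show what sets the two steps apart, as the pairs differ both in the core and in the surroundings of the place changed, and two pairs give no rule for the wider series.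

The compounds shown leave open what a group other than a halogen, such as a nitrile or an amine, would do at the place held by fluoro in compound 3 and bromo in compound 4. They also leave open whether the same exchange on a third core would follow the first pair, the second, or neither.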